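The compounds below may be only part of what the source reports. "The series", "measured", "known", "first", "only" and "open" are said of these compounds alone.

Of the compounds shown here, two have been measured in an assay on isolated protein for inhibition of proto-oncogene tyrosine-protein kinase receptor Ret (Homo sapiens), read by mobility shift assay, with a stated time of 1 h, tested at 10 uM; on this read-out lower numbers stand for less inhibition and higher numbers for more inhibition at the one concentration tested (going by the name of the read-out). Compound 1, with the structure `CN(C)CCn1cnnc1-c1cc(Oc2ccc(NC(=O)Nc3ccc(F)c(Cl)c3)cc2F)ccn1`, gives 63.3%. Compound 2, with the structure `CN(C)CCCn1cnnc1-c1cc(Oc2ccc(NC(=O)Nc3cccc(C(F)(F)F)c3)cc2F)ccn1`, gives 85.6%. Compound 2 therefore stands highest of the two numbers, and compound 1, its nearest neighbour, lies lower by a gap that is beyond the usual scatter of repeated measurements of this kind.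

The next compound, compound 3, has the structure `CN(C)CCCn1cnnc1-c1cc(Oc2ccc(NC(=O)Nc3ccc(F)c(Cl)c3)cc2F)ccn1`. It is reached from compound 2 by a single change: 3-chloro-4-fluorophenyl in place of 3-(trifluoromethyl)phenyl on an amide-type nitrogen. Within the data shown here, no measured pair differs in exactly this way, so the size of this step cannot be read directly from the data. Compound 3 does share the 3-chloro-4-fluorophenyl group with compound 1, whose value of 63.3% is lower than that of compound 2. On that basis compound 3 is expected to give about 72% in this assay, with a likely range from 55% to 88%. This corresponds to an expected step of a number 13.6 percentage points lower from compound 2 to compound 3 (beyond the scatter), a modest drop just beyond the scatter.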

Compound 3, a percentage reported as inhibition, at one concentration (the size of the read-out at that concentration, not a potency): 45.5%
Beside the measured number, compound 3's estimate is 26.5 percentage points above it, outside the stated range (below it).
By their numbers in this assay, from the lowest: compound 3; then compound 1; then compound 2.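

Among these compounds, for the first time, two compounds differ in only one place, and the aryl group on the amide-type nitrogen turns out to matter greatly: in this assay, 3-chloro-4-fluorophenyl in place of 3-(trifluoromethyl)phenyl gives a number 40.1 percentage points lower from compound 2 to compound 3 (beyond the scatter). The chain also affects the read-out, though this step is labelled modest rather than large: (dimethylamino)methyl in place of dimethylamino, on a saturated chain carbon two bonds along the chain from an aromatic nitrogen, gives a number 17.8 percentage points lower from compound 1 to compound 3 (beyond the scatter). Nothing measured here explains either step.

From the compounds shown here alone, each change is seen only once, against a single partner, so it remains open whether the aryl step would have the same size with the other chain, or whether the chain step would have the same size with 3-(trifluoromethyl)phenyl. Also open, going by these compounds, is how a morpholine in place of dimethylamino, or a longer chain, would read in this assay, and since all these numbers come from one concentration, they describe the size of inhibition at that concentration, not potency.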